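Three amides at the toxicity limit and a chlorophenyl newcomer

The compounds below may be only part of what the source reports. "The series", "measured", "known", "first", "only" and "open" are said of these compounds alone.

The series shares one core, carried first by compound 1 `CCOC(=O)CCCCCOc1cccc(CN(C(=O)c2ccc(-c3ccc4ccccc4c3)cc2)C(C)C)c1`. In an ADME assay on HepG2 cells (Homo sapiens) for cytotoxicity, read by CellTiter-Glo and resazurin assay, with a stated time of 72 h (a lower number here means that less compound is needed, a higher number that more compound is needed for the effect), compound 1 reaches only the limit of the assay, > 26000 nM. Compound 2 `CCOC(=O)CCCCCOc1cccc(CN(C(=O)c2ccc(-c3cccc(-c4nnc(C)o4)c3)cc2)C(C)C)c1` carries 3-(5-methyl-1,3,4-oxadiazol-2-yl)phenyl where compound 1 carries naphthalen-2-yl; in this assay compound 2 likewise gives only a limit, > 26000 nM. Compound 3 `CCOC(=O)CCCCCOc1cccc(CN(C(=O)c2ccc(-c3cc(OC)cc(OC)c3)cc2)C(C)C)c1` bears 3,5-dimethoxyphenyl on the same aromatic carbon, and in this assay compound 3 also stops at a limit, > 26000 nM. Compound 3 thus stands nowhere distinct among the three, every value shown being the same limit, which the limit of > 26000 nM in this assay, at which 3 of the 3 values shown sit, records. The steps a step that the two limits leave unreadable from compound 1 to compound 2, a step that the two limits leave unreadable from compound 1 to compound 3 and a step that the two limits leave unreadable from compound 2 to compound 3 cannot be sized.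

Compound 4 `CCOC(=O)CCCCCOc1cccc(CN(C(=O)c2ccc(-c3cccc(Cl)c3)cc2)C(C)C)c1` differs from compound 3 in one place: 3-chlorophenyl in place of 3,5-dimethoxyphenyl on an aromatic carbon. Only the three unreadable steps bear on this change, and none of them shows a toxicity below the limit, so the expectation is that compound 4 also stays at the limit in this assay. For compound 4 the estimated value in this assay is 40000 nM, with a range from 20000 nM to 100000 nM. The step that the limit leaves unreadable from compound 3 to compound 4 is therefore expected to be small, within the scatter.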

Compound 4, half-maximal effective concentration: > 18400 nM
Compound 4: a limit, no number; the forecaster's own chance of this, stated with the estimate: 85%; the middle value lies beyond the limit too.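

In this assay compound 4 gives only a limit, > 18400 nM. Compound 1, compound 2 and compound 3 also stop at limits, so none of the steps linking them to compound 4 can be read. The compounds shown leave open at what concentration any of the four reaches its half-maximal effect, and whether changing this aromatic substituent shifts that concentration at all.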